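Lipophilicity notes: aryl swap from compound 1 to compound 4

The source may hold more compounds than are shown below. What is called first, only, known or untested is meant among the compounds shown, and "the series" means these compounds.

Measured compounds:
compound 1 `CC(C)CN1C(=O)/C(=C/c2ccc(N(C)C)cc2)S/C1=N\c1ccccc1`: 5.49
compound 2 `CC(C)CN1C(=O)/C(=C/c2ccc([N+](=O)[O-])cc2)S/C1=N\c1ccccc1`: 5.32
compound 3 `CC(C)CN1C(=O)/C(=C/c2ccccn2)S/C1=N\c1ccccc1`: 4.4

In a physicochemical assay for lipophilicity, measured as octanol-water partition (a lower number here means a more polar compound, a higher number a more lipophilic compound), compound 1 stands highest of the three numbers; compound 2 lies within the scatter of it, with a number 0.17 log units lower from compound 1 to compound 2 (within the scatter), while compound 3 sits furthest below, with a number 1.09 log units lower from compound 1 to compound 3 (beyond the scatter).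

Compound 4 `CC(C)CN1C(=O)/C(=C/c2cccc(Cl)c2)S/C1=N\c1ccccc1` has not yet been measured in this assay. It differs from compound 1 as follows: 3-chlorophenyl in place of 4-(dimethylamino)phenyl on a double-bonded chain carbon bound to a double-bonded ring carbon. Among the measured compounds shown here, two measured steps bear on this. The step that keeps a phenyl ring and changes only its substituent, a number 0.17 log units lower from compound 1 to compound 2 (within the scatter), stayed within the scatter. The step that replaces the whole phenyl by pyridin-2-yl, a number 1.09 log units lower from compound 1 to compound 3 (beyond the scatter), was large. For the measured compounds named here, compound 4 keeps a phenyl ring, so the nearer precedent is the first one, and a step within the scatter, a number 0.06 log units higher from compound 1 to compound 4 (within the scatter), is expected. For compound 4 a value of 5.55 is estimated, in the range 5.15 to 5.95.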

Compound 4, partition coefficient: 5.98
The estimate for compound 4 lay 0.43 log units below the measured number; measured number above the stated range.
By their numbers in this assay, from the lowest: compound 3; then compounds 2 and 1 (each within the scatter of the next); then compound 4.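

In this assay a phenyl ring kept at this position does not by itself hold the number within the scatter, since the change to 3-chlorophenyl gives a number 0.49 log units higher from compound 1 to compound 4 (beyond the scatter) and a number 0.66 log units higher from compound 2 to compound 4 (beyond the scatter) as well. The same group set against pyridin-2-yl gives a number 1.58 log units higher from compound 3 to compound 4 (beyond the scatter) and the widest gap in the series, leaving compound 4 clear of all three others. No measured evidence is available to account for these steps.

The compounds shown leave open how 4-chlorophenyl compares with 3-chlorophenyl at this position. A phenyl ring bearing a carboxylic acid or a primary amine also remains unplaced in this order.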